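Swapping an Ester for Ethyl on the Pyridazinone Side Chain

The source may report more compounds than this note shows. Statements on the series, on what has been measured and on what is new or still open speak of the compounds shown alone.

Three compounds have so far been examined in an ADME assay on the whole organism (blood) for pharmacokinetics, with Canis familiaris (Canis lupus familiaris) as the target; on this read-out lower numbers stand for a shorter-lived compound and higher numbers for a longer-lived compound. Compound 1 `CC1(C)Oc2ccc(C#N)cc2[C@@H](N=C(NC#N)c2cccnc2)[C@@H]1O` gives 0.08 h. Compound 2 `CCCC1(C)Oc2ccc(C#N)cc2[C@@H](N=C(NC#N)c2cccnc2)[C@@H]1O`, which carries ethyl in place of hydrogen on a saturated chain carbon bound to a saturated ring carbon, gives 0.0167 h; the shift is a 4.8-fold lower number from compound 1 to compound 2 (0.68 log units; beyond the scatter). Compound 3 `COCC1(COC)Oc2ccc(C#N)cc2[C@@H](Nc2ccc(=O)n(CC(=O)OC)n2)[C@@H]1O` gives 0.025 h, which is within the scatter of compound 2 and sits below compound 1 by more than the scatter.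

The next compound, compound 4 `CCCn1nc(N[C@@H]2c3cc(C#N)ccc3OC(COC)(COC)[C@H]2O)ccc1=O`, differs from compound 3 in a single place: ethyl in place of methoxycarbonyl on a saturated chain carbon bound to an aromatic nitrogen. Within the data shown here, no measured step touches this part of the core; the only known step, the one from compound 1 to compound 2, concerns an alkyl chain at a different site, so it bears on the present change only loosely. Compound 4 is therefore expected to sit close to compound 3, with the estimated step of no change at the digits printed from compound 3 to compound 4 (within the scatter) falling within the usual scatter. The half-life of compound 4 is estimated at 0.025 h, likely between 0.01 h and 0.06 h.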

Compound 4, half-life: 0.0633 h
The estimate for compound 4 lay 2.5-fold (0.40 log units) below the measured number; the whole stated range lies below it.
By their numbers in this assay, from the lowest: compounds 2 and 3 (each within the scatter of the next); then compounds 4 and 1 (each within the scatter of the next).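

The pyridazinone side chain proves not to be a silent position in this assay, as ethyl in place of methoxycarbonyl on a saturated chain carbon bound to an aromatic nitrogen gives a 2.5-fold higher number from compound 3 to compound 4 (0.40 log units; beyond the scatter) and so moves the half-life by more than the scatter. This is the first step shown at this position, and its direction is upward, whereas the only earlier step, made at a different site on a different compound pair, was a 4.8-fold lower number from compound 1 to compound 2 (0.68 log units; beyond the scatter) and so ran downward. Nothing available accounts for the rise at this position.

With only the (methoxycarbonyl)methyl to propyl exchange in hand, the compounds do not show how the half-life would respond to a carboxylic acid, an amine or a longer chain on this aromatic nitrogen. They also leave open whether the same exchange would raise the number on the core of compound 1.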